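Adding a Methoxy Group: Expected Cytotoxicity of Compound 4

The source may hold more compounds than are shown below. What is called first, only, known or untested is meant among the compounds shown, and "the series" means these compounds.

Measured so far:
compound 1 `CCOC(=O)/C=C/c1cc(Cl)ccc1OC(=O)c1nc(C)c(C)nc1C`: 11%
compound 2 `CCOC(=O)/C=C/c1ccccc1OC(=O)c1nc(C)c(C)nc1C`: 40.9%
compound 3 `Cc1nc(C)c(C(=O)Oc2ccccc2/C=C/C(=O)O)nc1C`: 80.1%

Of the compounds shown here, three share one core and have been tested in a functional assay on EA.hy 926 cells (Homo sapiens) for cytotoxicity, read by MTT assay, with stated times of 24 h and 12 h, tested at 100 uM; on this read-out lower numbers stand for a weaker effect and higher numbers for a stronger effect at the one concentration tested. Compound 2 stands second highest of the three numbers; compound 1 lies below it, and compound 3 above it, both gaps beyond the scatter. Two single changes have been measured. The change from chloro to hydrogen on an aromatic carbon gave a number 29.9 percentage points higher from compound 1 to compound 2 (beyond the scatter). The change from ethyl to hydrogen on the oxygen next to the carbonyl gave a number 39.2 percentage points higher from compound 2 to compound 3 (beyond the scatter).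

Compound 4 `CCOC(=O)/C=C/c1ccc(OC)cc1OC(=O)c1nc(C)c(C)nc1C` is not yet measured. It differs from compound 2 as follows: methoxy in place of hydrogen on an aromatic carbon

Among the measured compounds shown here, only the step from compound 1 to compound 2 bears on a ring substituent, and there taking a chloro group off the ring raised the number. A methoxy group is not a chloro group, so that step is a loose guide at best. Compound 4 is therefore expected to land somewhat below compound 2, with a step of a number 10.9 percentage points lower from compound 2 to compound 4 (beyond the scatter), though a result within the scatter of compound 2 would not surprise. The estimate for compound 4 is 30%, with a range from 10% to 55%.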

Compound 4, a percentage reported as activity, at one concentration (the size of the read-out at that concentration, not a potency): 39.9%
Compound 4: middle estimate off by 9.9 percentage points, on the low side, within the range that was stated.
By their numbers in this assay, from the lowest: compound 1; then compounds 4 and 2 (each within the scatter of the next); then compound 3.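

In this assay, putting methoxy on the aromatic carbon para to a 2-(ethoxycarbonyl)ethenyl group and meta to a large group gave a number 1 percentage points lower from compound 2 to compound 4 (within the scatter) and so no step beyond the scatter. Among the compounds shown here, the only earlier ring change, a number 29.9 percentage points higher from compound 1 to compound 2 (beyond the scatter), concerned a chloro group on a different aromatic carbon, so the new result shows that a substituent on the ring of this series need not come with a shift in the number. No measurement shown here offers an explanation for this result.

As far as these compounds go, whether an amine or a longer alkoxy chain on this same aromatic carbon would give a number clearly apart from that of compound 2 remains open. Also open, from the compounds shown here alone, is whether methoxy at this position would leave the number unchanged in the carboxylic acid, compound 3, rather than in the ethyl ester.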